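A few compounds are considered here, and "the series" means these few. Any claim that something is new, unique, unknown or untested is made for them only; others in the source may bear on it.

Working notes on the series built around the core of compound 1 `Cn1c(-c2ccccc2)cnc1NC(=O)c1ccccc1`. In a toxicity assay on THP-1 cells (Homo sapiens) for inhibition (a lower number here means that less compound is tolerated, a higher number that more compound is tolerated), compound 1 reaches only the limit > 100000 nM. Compound 2 `COc1ccc(-c2cnc(NC(=O)c3ccc([N+](=O)[O-])cc3)n2C)cc1` in this assay likewise stops at the limit > 100000 nM. Compound 3 `COc1ccc(-c2cnc(NC(=O)c3ccccc3)n2C)cc1` in this assay also gives the limit > 100000 nM. The steps a step that the two limits leave unreadable from compound 1 to compound 3 and a step that the two limits leave unreadable from compound 2 to compound 3 therefore cannot be sized, as the limit of > 100000 nM in this assay, at which 3 of the 3 values shown sit, is the only mark in view for all three compounds. Compound 4 `COc1ccc(-c2cnc(NC(=O)c3cccc(C)c3)n2C)cc1` differs from compound 3 by methyl in place of hydrogen on an aromatic carbon. Within the data shown here, no measured step bears directly on this change, and with every value at the limit no step beyond the scatter is expected in this assay. Compound 4 is thus estimated at 100000 nM, with a range from 30000 nM to 300000 nM, which means an expected step of a number no higher from compound 3 to compound 4 (the limit leaves the size open).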

Compound 4, half-maximal cytotoxic concentration: > 100000 nM
Compound 4 was reported as a limit; the forecaster's own chance of this, stated with the estimate: 85%; the middle value sits exactly at the limit.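

No step can be read between compound 3 and compound 4 in this assay, as both values are limits: the limit of > 100000 nM in this assay, at which 4 of the 4 values shown sit. The compounds shown leave open at what concentration any member of the series reaches half-maximal cytotoxicity, and whether any substituent shifts it.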